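The source may hold more compounds than are shown below. What is called first, only, known or untested is meant among the compounds shown, and "the series" means these compounds.

Compound 2 `C=C1[C@@H](OC(C)=O)C[C@@H]2[C@](C)(CO[Si](C)(C)C(C)(C)C)[C@H](OC(C)=O)CC[C@@]2(C)[C@@H]1C[C@@H](Nc1ccc(C(=O)O)cc1)C1=CCOC1=O` gives 5540 nM in a functional assay on KB cells (Homo sapiens) for cytotoxicity, read by sulforhodamine B assay; on this read-out lower numbers stand for stronger inhibition and higher numbers for weaker inhibition. Among the two plain numbers it is the higher, yet its nearest neighbour compound 1 `C=C1[C@@H](OC(C)=O)C[C@@H]2[C@](C)(CO[Si](C)(C)C(C)(C)C)[C@H](OC(C)=O)CC[C@@]2(C)[C@@H]1C[C@@H](Nc1ccccc1F)C1=CCOC1=O`, which gives 4740 nM in this assay, lies within the usual scatter: a 1.2-fold higher number from compound 1 to compound 2 (0.07 log units; within the scatter). Compound 3 `C=C1[C@@H](OC(C)=O)C[C@@H]2[C@](C)(COC=O)[C@H](OC(C)=O)CC[C@@]2(C)[C@@H]1C[C@@H](Nc1ccc(C(=O)O)cc1)C1=CCOC1=O` reaches only the assay limit, > 50000 nM. That step, an at least 9.0-fold higher number from compound 2 to compound 3 (0.95 log units; beyond the scatter), concerns an oxygen on a saturated carbon and not the amine nitrogen. Compound 4 `C=C1[C@@H](OC(C)=O)C[C@@H]2[C@](C)(CO[Si](C)(C)C(C)(C)C)[C@H](OC(C)=O)CC[C@@]2(C)[C@@H]1C[C@@H](Nc1ccc(OC)c(OC)c1)C1=CCOC1=O` differs from compound 2 at the amine nitrogen alone: 3,4-dimethoxyphenyl in place of 4-carboxyphenyl on an amine nitrogen. Going by the values given here, the one measured step at that place, a 1.2-fold higher number from compound 1 to compound 2 (0.07 log units; within the scatter), stayed within the scatter, so for compound 4 no step beyond the scatter is expected, a 1.0-fold lower number from compound 2 to compound 4 (0.00 log units; within the scatter). Compound 4 is therefore estimated at 5500 nM, between 2500 nM and 12000 nM.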

Compound 4, half-maximal inhibitory concentration: 5800 nM
Compound 4: middle estimate off by 1.1-fold (0.02 log units), on the low side; low and high end bracket the measured number.
By their numbers in this assay, from the lowest: compounds 1, 2 and 4 (each within the scatter of the next). At a limit, above all of these: compound 3.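

At this position, a third aryl group leaves the read-out in this assay within the scatter: a 1.0-fold higher number from compound 2 to compound 4 (0.02 log units; within the scatter), and a 1.2-fold higher number from compound 1 to compound 4 (0.09 log units; within the scatter). The 2-fluorophenyl, 4-carboxyphenyl and 3,4-dimethoxyphenyl groups thus read alike here, even though 3,4-dimethoxyphenyl has no hydrogen-bond donor and 4-carboxyphenyl has one. Nothing measured here explains this likeness. On these data alone, whether the amine nitrogen accepts a group other than a substituted phenyl, such as a pyridine ring or a butyl chain, remains open. So does whether the aryl groups would still read alike with the formate ester of compound 3 in place of the silyl ether.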